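Chlorophenyl on the piperidine of compound 2

The compounds below may be only part of what the source reports. "The series", "measured", "known", "first", "only" and "open" are said of these compounds alone.

Measured in (an ADME assay (liver) for metabolic stability, with Liver microsome (Homo sapiens) as the target, using microsomes; on this read-out higher numbers stand for a longer-lived compound and lower numbers for a shorter-lived compound):
Compound 1 (`CCc1nc2cc(Cl)ccn2c1C(=O)NCc1ccc(-c2ccc(Cl)cc2)cc1`): (> 2 h), a limit of the assay
Compound 2 (`CCc1nc2cc(Cl)ccn2c1C(=O)NCc1ccc(N2CCC(Cl)CC2)cc1`): (0.183 h)

Among the compounds with values here, compound 2 holds the only actual number here (0.183 h). The reading for compound 1 is a limit (the limit of > 2 h in this assay, at which 1 of the 2 values shown sits). Compound 3 (`CCc1nc2cc(Cl)ccn2c1C(=O)NCc1ccc(N2CCC(c3ccc(Cl)cc3)CC2)cc1`) has 4-chlorophenyl in place of chloro on a saturated ring carbon. Within the data shown here, the one measured step bearing on this is large (an at least 10-fold lower number from compound 1 to compound 2 (1.03 log units; beyond the scatter)), with 4-chloropiperidin-1-yl in place of 4-chlorophenyl on an aromatic carbon. Since 4-chlorophenyl returns in a new place, a rise of only part of that size is expected in this assay. The expected step is modest (a 3.8-fold higher number from compound 2 to compound 3 (0.58 log units; beyond the scatter)). Compound 3 is estimated at (0.7 h), with an expected range from (0.25 h) to (2 h).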

Compound 3, half-life: 1.12 h
Compound 3: middle estimate off by 1.6-fold (0.20 log units), on the low side; measured number inside the range.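

In this assay, putting 4-chlorophenyl in place of chloro on the saturated ring carbon, three ring bonds from the ring nitrogen, gives a longer-lived compound, with a 6.1-fold higher number from compound 2 to compound 3 (0.79 log units; beyond the scatter). The short half-life of compound 2 therefore does not go with the piperidine ring alone: with that ring kept, the group on this carbon moves the read-out beyond the scatter.

Compound 1 reads only as a limit, so its distance from compound 3 cannot be sized: the limit of > 2 h in this assay, at which 1 of the 3 values shown sits. As far as these compounds go, whether a plain phenyl, a 4-fluorophenyl or a carboxylic acid on this carbon would act alike stays open.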